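Replacing the ethoxy group on the shared core

This account rests on a few compounds, and the source may have more. Where it says the series, first, only, none or still open, it means among the compounds named here.

Measured so far in an assay on cells (Ventricular myocyte) for inhibition of potassium voltage-gated channel subfamily KQT member 1 (Cavia porcellus), read by patch clamp; a lower number here means a stronger inhibitor, a higher number a weaker inhibitor:
compound 2 `COc1ccc2c(c1)/C(=N/N1CC(=O)N(CCCN3CCN(C)CC3)C1=O)CCO2` gives 1.9 nM
compound 3 `CCOc1ccc2c(c1)/C(=N/N1CC(=O)N(CCCN3CCN(C)CC3)C1=O)CCO2` gives 26.9 nM
compound 1 `Cc1ccc2c(c1)/C(=N/N1CC(=O)N(CCCCN3CCCCC3)C1=O)CCO2` gives 18900 nM

Compound 3 stands second highest of the three numbers in this assay; compound 2 is nearest, and compound 1 lies furthest away with a far higher number. Compound 4 `Cc1ccc2c(c1)/C(=N/N1CC(=O)N(CCCN3CCN(C)CC3)C1=O)CCO2` is not yet measured. It differs from compound 3 by methyl in place of ethoxy on an aromatic carbon. Going by the values given here, the only measured step that touches this part of the core is a 14-fold higher number from compound 2 to compound 3 (1.15 log units; beyond the scatter); enlarging the group at that position therefore cost potency noticeably. Among the compounds with values here, compound 1 also carries the methyl on the aromatic ring but has a different amine chain, so its value cannot be separated from that chain change and no step to compound 4 is available. With the oxygen acceptor removed from the aromatic substituent, compound 4 is expected to give a higher number than compound 3, a step estimated at a 7.4-fold higher number from compound 3 to compound 4 (0.87 log units; beyond the scatter). The estimate for compound 4 in this assay is 200 nM, with a range from 25 nM to 2000 nM.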

Compound 4, half-maximal inhibitory concentration: 304 nM
Estimate against measurement, compound 4: 1.5-fold (0.18 log units) below, and the stated range covers the measured number.
By their numbers in this assay, from the lowest: compound 2; then compound 3; then compound 4; then compound 1.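

In this assay, methyl in place of ethoxy gives an 11-fold higher number from compound 3 to compound 4 (1.05 log units; beyond the scatter), and methyl in place of methoxy gives a 160-fold higher number from compound 2 to compound 4 (2.20 log units; beyond the scatter), so with this amine chain both oxygen-linked groups on this aromatic carbon give lower numbers than methyl. The number therefore does not rise steadily with group size: methoxy gives the lowest, then ethoxy, then the smaller methyl. With the aromatic methyl held constant, 4-methylpiperazin-1-yl in place of (piperidin-1-yl)methyl gives a 62-fold lower number from compound 1 to compound 4 (1.79 log units; beyond the scatter), so the amine chain change alone accounts for a large step.

Still open, on these data alone, is how a hydroxyl, a chlorine or a propoxy chain at this aromatic carbon would compare, and whether methoxy keeps its lead on the piperidine chain. No measurement shown here explains these steps.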